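The source may report more compounds than this note shows. Statements on the series, on what has been measured and on what is new or still open speak of the compounds shown alone.

Compounds measured so far in a functional assay on MCF7 cells (Homo sapiens) for antiproliferative activity; on this read-out higher numbers stand for weaker inhibition and lower numbers for stronger inhibition:

- compound 1 `O=c1oc2cc(O)ccc2c(-c2cccc(OCCCCCN3CCCCC3)c2)c1-c1ccccc1`: 15 nM
- compound 2 `O=c1oc2cc(O)ccc2c(-c2ccc(OCCCN3CCCCC3)cc2)c1-c1ccccc1`: 335 nM
- compound 3 `O=c1oc2cc(O)ccc2c(-c2ccc(OCCCCN3CCCCC3)cc2)c1-c1ccccc1`: 134 nM

Compound 1 gives the lowest number of the three in this assay. Compound 3 is nearest to it, with a number higher by a margin beyond the scatter, and compound 2 is furthest. Compound 2 and compound 3 each differ from compound 1 in two places at once, so their gaps to compound 1 are read only as values, not as single steps.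

The unmeasured compound 4 `O=c1oc2cc(O)ccc2c(-c2cccc(OCCCCN3CCCCC3)c2)c1-c1ccccc1` differs from compound 1 in one place: piperidin-1-yl in place of (piperidin-1-yl)methyl on a saturated chain carbon, four bonds along the chain from an oxygen on an aromatic ring. Read one bond further out, the same change is 4-(piperidin-1-yl)butyl to 3-(piperidin-1-yl)propyl.

For the measured compounds named here, the one measured step that bears on this is a 2.5-fold lower number from compound 2 to compound 3 (0.40 log units; beyond the scatter), which runs the same chain change in the opposite direction, on a different attachment of the aryl ether. Taken in reverse, it points to a modest rise in number for compound 4 in this assay. Whether the attachment seen in compound 1 behaves the same way is not known from these three compounds, so the range is kept wide.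

The estimate for compound 4 in this assay is 40 nM, between 15 nM and 110 nM, a step of a 2.7-fold higher number from compound 1 to compound 4 (0.43 log units; beyond the scatter) expected from compound 1.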

Compound 4, half-maximal inhibitory concentration: 12 nM
For compound 4 the middle estimate is 3.3-fold (0.52 log units) above the measured one, and the stated range ends above it.
By their numbers in this assay, from the lowest: compounds 4 and 1 (each within the scatter of the next); then compound 3; then compound 2.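

In this assay, putting piperidin-1-yl in place of (piperidin-1-yl)methyl at this place on the core of compound 1 gives a 1.3-fold lower number from compound 1 to compound 4 (0.10 log units; within the scatter), so on this core the shorter chain leaves the number unresolved from that of the longer one. Compound 3 carries the same chain as compound 4 on the other attachment of the aryl ether, and there compound 3 gives 134 nM while compound 4 gives 12 nM, a pair that differs only in that attachment. The chain change therefore does not read the same on the two cores: the same change on two cores in this assay, a 2.5-fold lower number (0.40 log units; beyond the scatter) from compound 2 to compound 3 and a 1.3-fold higher number (0.10 log units; within the scatter) from compound 4 to compound 1, 3.1-fold (0.49 log units) apart, beyond the scatter of two such steps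

The compounds shown leave open how far the chain on the core of compound 1 can be changed before the number moves, for example with 3-(piperidin-1-yl)propyl or with a chain longer than that of compound 1. They also leave open whether a morpholine or a dimethylamine in place of the piperidine would hold the value on this core, and what lies behind the difference between the two cores cannot be read from them.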